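Cyclohexyl to pyridin-3-yl on the side chain of compound 2

This account rests on a few compounds, and the source may have more. Where it says the series, first, only, none or still open, it means among the compounds named here.

Measured so far in a functional assay on HeLa cells (Homo sapiens) for cytotoxicity, read by WST assay, with a stated time of 48 h; on this read-out lower numbers stand for stronger inhibition and higher numbers for weaker inhibition:
compound 1 `COc1ccc(/C=C/C[C@@H]2C[C@@H]([C@@H](O)c3ccc(OC)c(OC)c3)CO[C@H]2c2ccc(OC)c(OC)c2)cc1OC` gives 30600 nM
compound 2 `O[C@@H](c1ccccc1)[C@H]1CO[C@H](c2ccccc2)[C@@H](C/C=C/C2CCCCC2)C1` gives 6440 nM

Within the data shown here, compound 2 holds the lower of the two numbers; compound 1 sits beyond the scatter above it, though the two differ in several places and no single step links them. Compound 3 `O[C@@H](c1ccccc1)[C@H]1CO[C@H](c2ccccc2)[C@@H](C/C=C/c2cccnc2)C1` keeps the core of compound 2 and changes one group: pyridin-3-yl in place of cyclohexyl on a double-bonded chain carbon bound to a double-bonded chain carbon. Among the measured compounds shown here, no measured step of this kind exists, so the expected move from compound 2 to compound 3 in this assay is small, about a 1.4-fold higher number from compound 2 to compound 3 (0.15 log units; within the scatter), likely within the scatter. Compound 3 is therefore estimated at 9000 nM, with a range from 3000 nM to 30000 nM.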

Compound 3, half-maximal inhibitory concentration: > 100000 nM
Compound 3: a limit, no number; the forecaster's own chance of this, stated with the estimate: 5%; at least 11-fold (1.04 log units) between middle value and limit.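

In this assay, this place on a double-bonded chain carbon bound to a double-bonded chain carbon proves sensitive to the ring it carries: pyridin-3-yl in place of cyclohexyl gives an at least 15-fold higher number from compound 2 to compound 3 (1.19 log units; beyond the scatter). Compound 3 gives > 100000 nM, which is a limit of the assay and not a number. The reading of this step rests on that limit: the limit of > 100000 nM in this assay, at which 1 of the 3 values shown sits.

Going by these compounds, whether a piperidine ring at this place would track cyclohexyl or pyridin-3-yl remains open. The ring nitrogen and the aromatic ring therefore cannot yet be separated as the source of the loss.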